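The source may hold more compounds than are shown below. What is called first, only, known or untested is meant among the compounds shown, and "the series" means these compounds.

Two compounds share one core and differ only in the group sitting on a saturated chain carbon bound to a sulfur. Compound 1 `Cc1ccc(CSc2cc(Cl)c(C)cc2S(=O)(=O)/N=C(\N)n2nccc2-c2ccccc2)cc1` carries 4-methylphenyl there, and in an ADME assay on microsomes from liver (Homo sapiens) for metabolic stability, read by LC-MS, using NADPH, tested at 5 uM (on this read-out lower numbers stand for a shorter-lived compound and higher numbers for a longer-lived compound), compound 1 gives 0.13 h. Compound 2 `Cc1cc(S(=O)(=O)/N=C(\N)n2nccc2-c2ccccc2)c(SCc2ccccc2Cl)cc1Cl` carries 2-chlorophenyl instead, and in this assay compound 2 gives 0.226 h. Compound 2 stands at one end of these two numbers and compound 1 at the other, yet the step of a 1.7-fold higher number from compound 1 to compound 2 (0.24 log units; within the scatter) lies within the scatter, so this assay does not tell the two apart.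

The unmeasured compound 3 `Cc1cc(S(=O)(=O)/N=C(\N)n2nccc2-c2ccccc2)c(SCc2ccc(Cl)cc2)cc1Cl` is built from the same atoms joined differently: 4-chlorophenyl in place of 2-chlorophenyl on a saturated chain carbon bound to a sulfur. Within the data shown here, no measured pair compares a 2-chlorophenyl with a 4-chlorophenyl at this place. Among the measured compounds shown here, the only step that bears on it, a 1.7-fold higher number from compound 1 to compound 2 (0.24 log units; within the scatter), swapped one ring for another on this same chain carbon and stayed within the scatter. The expectation for this assay is therefore a step no larger than the scatter, in no firm direction, which is written as a 1.3-fold lower number from compound 2 to compound 3 (0.10 log units; within the scatter). For compound 3 the estimated half-life in this assay is 0.18 h, with a range from 0.08 h to 0.4 h.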

Compound 3, half-life: 0.34 h
Beside the measured number, compound 3's estimate is 1.9-fold (0.28 log units) below it; the range from low to high includes it.
By their numbers in this assay, from the lowest: compounds 1, 2 and 3 (each within the scatter of the next, the first and the last beyond it).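

Swapping 2-chlorophenyl for 4-chlorophenyl on a saturated chain carbon bound to a sulfur gives (a 1.5-fold higher number from compound 2 to compound 3 (0.18 log units; within the scatter)) in this assay, so this assay cannot separate the two placements of the chlorine. Among these compounds, the comparison of compound 3 with compound 1 is the first step here to pass the scatter: with chloro in place of methyl on an aromatic carbon, 4-methylphenyl becoming 4-chlorophenyl, the result is (a 2.6-fold higher number from compound 1 to compound 3 (0.42 log units; beyond the scatter)), a modest change resting on this single pair, which shows that the small group on this ring can shift the half-life even though compound 2 cannot be separated from either neighbour. No supporting measurement is available that would explain either step.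

From the compounds shown here alone, with only methyl and chloro on this ring, it remains open how a fluoro, a methoxy, an amine or a carboxylic acid in the same place would read in this assay. Also open, going by these compounds, is whether the half-life would hold if the phenyl ring were replaced by a simple longer alkyl chain on the same sulfur-bound carbon.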